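This account rests on a few compounds, and the source may have more. Where it says the series, first, only, none or still open, it means among the compounds named here.

Working notes on the series.

Three compounds of the shared core have numbers in an assay on isolated protein for binding affinity to corticotropin-releasing factor receptor 1 (Homo sapiens); on this read-out higher numbers stand for weaker inhibition and lower numbers for stronger inhibition. Compound 1 `CCCN(Cc1ccccc1)c1cc(C)nc2c(-c3ncc(C(F)(F)F)cc3Cl)c(C)nn12` gives 1.7 nM, compound 2 `CCCN(CCC)c1cc(C)nc2c(-c3ncc(N4CCCCC4)cc3C)c(C)nn12` gives 17 nM, and compound 3 `CCCN(CCC)c1cc(C)nc2c(-c3ncc(N=O)cc3C)c(C)nn12` gives 100 nM. Compound 3 thus stands highest of the three: compound 2 is the nearest, and compound 1 the furthest, both well beyond the scatter.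

Within the data shown here, the one single-place step known, a 5.9-fold higher number from compound 2 to compound 3 (0.77 log units; beyond the scatter), concerns the same aromatic carbon of the pyridine that carries the change now at hand. Compound 4 `CCCN(CCC)c1cc(C)nc2c(-c3ncc(C)cc3O)c(C)nn12` differs from compound 3 in that (a group of 8 heavy atoms (6 carbon, 1 nitrogen, 1 oxygen; one six-membered aromatic ring with 1 hetero atom) in place of a group of 9 heavy atoms (6 carbon, 2 nitrogen, 1 oxygen; one six-membered aromatic ring with 1 hetero atom), on an aromatic carbon). Among the measured compounds shown here, no measured pair mirrors this exchange; the known step only shows that substitution on that pyridine moves this assay by a modest amount, in either direction.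

A modest step back downward is therefore expected, a 2.5-fold lower number from compound 3 to compound 4 (0.40 log units; beyond the scatter), with wide uncertainty. Compound 4 is estimated at 40 nM in this assay, within 8 nM to 200 nM.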

Compound 4, inhibition constant: > 10000 nM
Compound 4 ended at the assay's limit; the forecaster's own chance of this, stated with the estimate: 3%; at least 250-fold (2.39 log units) between middle value and limit.
By their numbers in this assay, from the lowest: compound 1; then compound 2; then compound 3. At a limit, above all of these: compound 4.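

In this assay, among these compounds, the exchange on this aromatic carbon of the five-membered ring, which brings in 3-hydroxy-5-methylpyridin-2-yl, gives an at least 100-fold higher number from compound 3 to compound 4 (2.00 log units; beyond the scatter), whereas the only earlier step, a 5.9-fold higher number from compound 2 to compound 3 (0.77 log units; beyond the scatter), was modest. The group at this place can therefore take the read-out from a measurable number to the end of its range, and the entering group carries 1 hydrogen-bond donor where the leaving group has 0. The value for compound 4 is a limit and not a number, so the true size of the step stays unknown: the limit of > 10000 nM in this assay, at which 1 of the 4 values shown sits.

The compounds shown leave open whether the hydroxy group alone goes with this step or the exchange as a whole does. A methoxy group in place of that hydroxy, with the rest of compound 4 unchanged, would bear on this.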